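Sulfanyl-methyl substituent swap in an adenosine receptor series

This account rests on a few compounds, and the source may have more. Where it says the series, first, only, none or still open, it means among the compounds named here.

Measured compounds:
Compound 1 `CCOc1ccc(-c2c(C#N)c(N)nc(SCc3ccn[nH]3)c2C#N)cc1` gives 21 nM in an assay on CHO cells for displacement of a labelled ligand from adenosine receptor A1 (Homo sapiens), read by scintillation counting, with a stated time of 90 min; on this read-out lower numbers stand for stronger inhibition and higher numbers for weaker inhibition.
Compound 2 `CCOc1ccc(-c2c(C#N)c(N)nc(SCC(N)=O)c2C#N)cc1` gives 345 nM in this assay.
Compound 3 `CCOc1ccc(-c2c(C#N)c(N)nc(SCc3ncc[nH]3)c2C#N)cc1` gives 8.2 nM in this assay.

Compound 3 holds the lowest number of the three. Its nearest neighbour lies one modest step away, a 2.6-fold lower number from compound 1 to compound 3 (0.41 log units; beyond the scatter); its furthest lies a large step away, a 42-fold lower number from compound 2 to compound 3 (1.62 log units; beyond the scatter).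

Compound 4 `CCOc1ccc(-c2c(C#N)c(N)nc(SCC(=O)NC)c2C#N)cc1` is not yet measured. The change from compound 3 is methylcarbamoyl in place of 1H-imidazol-2-yl on a saturated chain carbon bound to a sulfur. Going by the values given here, two measured steps bear on it. The reverse of the same kind of exchange, a 42-fold lower number from compound 2 to compound 3 (1.62 log units; beyond the scatter), was large, and a 16-fold higher number from compound 1 to compound 2 (1.22 log units; beyond the scatter) likewise showed the carbamoyl-bearing compound 2 far weaker than its ring-bearing partner. Among the compounds with values here, compound 4 carries a methylcarbamoyl, which shares the carbamoyl of compound 2 and carries no ring; no measured compound tells what the added methyl does. A large rise in this assay is therefore expected, a 37-fold higher number from compound 3 to compound 4 (1.56 log units; beyond the scatter), landing near the value of compound 2.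

Compound 4 is estimated at 300 nM in this assay, within a range of 90 nM to 1000 nM.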

Compound 4, inhibition constant: 104 nM
Beside the measured number, compound 4's estimate is 2.9-fold (0.46 log units) above it; low and high end bracket the measured number.
By their numbers in this assay, from the lowest: compound 3; then compound 1; then compound 4; then compound 2.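

In this assay, the amide end of this substituent proves sensitive to a very small change: methyl in place of hydrogen on an amide-type nitrogen gives a modest gain (a 3.3-fold lower number from compound 2 to compound 4 (0.52 log units; beyond the scatter)). That gain closes only part of the distance to the ring-bearing compounds, since methylcarbamoyl still stands well behind 1H-imidazol-2-yl (a 13-fold higher number from compound 3 to compound 4 (1.10 log units; beyond the scatter)) and 1H-pyrazol-5-yl (a 5.0-fold higher number from compound 1 to compound 4 (0.69 log units; beyond the scatter)) on the saturated chain carbon bound to a sulfur. No supporting data on why these exchanges change the numbers accompany the series.

Open, on these data alone, is whether an ethyl or a second methyl on the amide nitrogen would extend the gain seen with methyl. Also open, as far as these compounds go, is how a carboxylic acid, an amine or a longer chain carrying the amide would read at this position.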